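Swapping a chloro for dimethylamino on a thromboxane synthase inhibitor

The source may report more compounds than this note shows. Statements on the series, on what has been measured and on what is new or still open speak of the compounds shown alone.

Measured so far:
compound 1, `CCn1cc(Cn2ccnc2)c2ccccc21`: 8.4 nM
compound 2, `O=C(O)CCn1cc(Cn2ccnc2)c2cc(Cl)ccc21`: 21 nM

In an assay for inhibition of Thromboxane-A synthase (Homo sapiens) (a lower number here means a stronger inhibitor, a higher number a weaker inhibitor), compound 2 gives 21 nM, the higher of the two numbers; compound 1 gives 8.4 nM, and the gap between them is beyond the usual scatter. Compound 3, `CN(C)c1ccc2c(c1)c(Cn1ccnc1)cn2CCC(=O)O`, has not been measured. It differs from compound 2 in one place: dimethylamino in place of chloro on an aromatic carbon. Among the compounds with values here, no measured pair shows this change, so the expected step of a 1.2-fold higher number from compound 2 to compound 3 (0.08 log units; within the scatter) is small and in no clear direction, within the scatter. Compound 3 is therefore expected to give about 25 nM, between 8 nM and 80 nM.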

Compound 3, half-maximal inhibitory concentration: 82 nM
Estimate against measurement, compound 3: 3.3-fold (0.52 log units) below; the measured number lies above the stated range.
By their numbers in this assay, from the lowest: compound 1; then compound 2; then compound 3.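

In this assay, this aromatic carbon is sensitive to the group it carries: dimethylamino in place of chloro gives a 3.9-fold higher number from compound 2 to compound 3 (0.59 log units; beyond the scatter), a weaker inhibitor. The earlier compounds shown here could not show this, as they offered no comparison differing only at this place. No measurement at hand explains the shift.

The compounds shown leave open whether fluoro, methoxy or a plain hydrogen at this carbon would match chloro or fall closer to dimethylamino. They also leave open whether a smaller amine, such as methylamino, would behave like dimethylamino.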